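A Methyl Added to the Dimethoxyphenyl Ring

The source may hold more compounds than are shown below. What is called first, only, known or untested is meant among the compounds shown, and "the series" means these compounds.

Measured compounds:
Compound 1, `CCc1nn2c(-c3c(OC)cccc3OC)cccc2c1N(CC1CCOCC1)CC1CC1`, gives 3300 nM.
Compound 2, `COCc1cc(OC)c(-c2cccc3c(N(CC4CCOCC4)CC4(O)CC4)c(SC)nn23)c(OC)c1`, gives 26000 nM.

Both numbers come from a physicochemical assay for solubility, in phosphate buffer, measured as kinetic solubility; a higher number here means a more soluble compound, a lower number a less soluble compound. Compound 1 stands lowest of the two, and the gap to compound 2 lies beyond the usual scatter of this kind of measurement. Among the compounds with values here, compound 2 differs from compound 1 in several places at once, so no single-change step between measured compounds is available to guide the next move.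

Compound 3, `CCc1nn2c(-c3c(OC)cc(C)cc3OC)cccc2c1N(CC1CCOCC1)CC1CC1`, differs from compound 1 in one place only: methyl in place of hydrogen on an aromatic carbon.

Within the data shown here, with no measured step of this kind to lean on, the expectation rests on compound 1 alone. The step from compound 1 to compound 3 is expected to be small and downward, quite possibly not beyond the scatter: a 1.5-fold lower number from compound 1 to compound 3 (0.18 log units; within the scatter). Compound 3 is therefore estimated at 2200 nM, with a likely range from 900 nM to 5500 nM.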

Compound 3, solubility: 1600 nM
Compound 3: the middle estimate sits 1.4-fold (0.14 log units) above what was measured; the measured number falls inside the stated range.
By their numbers in this assay, from the lowest: compound 3; then compound 1; then compound 2.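

The ring carbon para to a large group and meta to two methoxy groups is not a silent spot in this assay: one methyl placed there gives a 2.1-fold lower number from compound 1 to compound 3 (0.31 log units; beyond the scatter) and so moves the number modestly but beyond the usual scatter. Within the data shown here, this is the first change here that can be tied to a single place, whereas the gap between compound 1 and compound 2 spreads over several differences at once. No measurement shown explains the drop.

One step at one position cannot say whether other groups would follow the same direction. Going by these compounds, whether an amine or a carboxylic acid on this carbon would raise the number, and whether a longer chain would lower it further than methyl does, stays open.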